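The source may hold more compounds than are shown below. What is called first, only, known or untested is meant among the compounds shown, and "the series" means these compounds.

Values in a functional assay on HUVEC cells (Homo sapiens) for inhibition, tested at 10 ug/mL; a higher number here means a stronger effect of the compound at the concentration tested, a lower number a weaker effect:
compound 1 `CCOC(=O)C(=O)Nc1cccc(C(=O)/C=C/c2ccc(O)c(OC)c2)c1` gives 66%
compound 2 `COc1cc(/C=C/C(=O)c2cccc(NC(=O)c3cccs3)c2)ccc1O` gives 90%
compound 3 `COc1cc(/C=C/C(=O)c2cccc(NC(=O)c3c(Cl)cccc3Cl)c2)ccc1O` gives 99%

Compound 3 stands highest on the numbers shown; its gap to compound 2 lies within the scatter (a number 9 percentage points higher from compound 2 to compound 3 (within the scatter)), so no order between these two is claimed, whereas its gap to compound 1 lies beyond it (a number 33 percentage points higher from compound 1 to compound 3 (beyond the scatter)). Compound 4 `COc1cc(/C=C/C(=O)c2cccc(NC(C)=O)c2)ccc1O` is to be measured next. Its change from compound 3: methyl in place of 2,6-dichlorophenyl on a carbonyl carbon.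

Within the data shown here, two measured steps bear on this. The step of a number 33 percentage points higher from compound 1 to compound 3 (beyond the scatter) shows that an ethoxycarbonyl on that carbonyl carbon gives a markedly lower number than the 2,6-dichlorophenyl, while the step of a number 9 percentage points higher from compound 2 to compound 3 (within the scatter) shows a thiophen-2-yl there landing within the scatter of it. Methyl, like ethoxycarbonyl, carries no ring, so a drop beyond the scatter is expected, of a size near the reverse of the step from compound 1, with wide uncertainty; compound 1 is the only measured compound without a ring at that position. The expected step is a number 34 percentage points lower from compound 3 to compound 4 (beyond the scatter). For compound 4 the estimate in this assay is 65%, with a range from 40% to 88%.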

Compound 4, a percentage reported as inhibition, at one concentration (the size of the read-out at that concentration, not a potency): 32%
Compound 4: middle estimate off by 33 percentage points, on the high side, outside the stated range (below it).
By their numbers in this assay, from the lowest: compound 4; then compound 1; then compounds 2 and 3 (each within the scatter of the next).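

In this assay, methyl on the carbonyl carbon gives a lower number than each of the other three groups (a number 67 percentage points lower from compound 3 to compound 4 (beyond the scatter); a number 58 percentage points lower from compound 2 to compound 4 (beyond the scatter); a number 34 percentage points lower from compound 1 to compound 4 (beyond the scatter)). The last step shows that the lack of a ring does not alone set the level at this position: methyl and ethoxycarbonyl both carry no ring, yet they differ beyond the scatter, and compound 4 stands lowest of the four. Nothing measured here accounts for these steps.

From the compounds shown here alone, whether a longer chain such as propyl on that carbonyl carbon would restore part of the effect remains open. Also open, going by these compounds, is whether an unsubstituted phenyl would reach the level of the 2,6-dichlorophenyl, which would show whether its two chlorines are needed.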